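The source may hold more compounds than are shown below. What is called first, only, known or untested is meant among the compounds shown, and "the series" means these compounds.

In an ADME assay on NIH3T3 cells (Mus musculus) for cytotoxicity, read by WST assay, with a stated time of 72 h (on this read-out lower numbers stand for higher toxicity in this test and higher numbers for lower toxicity in this test), compound 1 `CCCCCCCC/C=C\c1c(C)c(/C=C\CCCCCCCC)c2[n+](c1C)CCC2` gives 23.5 uM and compound 2 `CCCCCCCC/C=C\c1c(C)c(/C=C/CCCCCCCC)c(C)[n+]2c1CCC2` gives 4 uM, the lower of the two numbers. For the measured compounds named here, the one measured step is a 5.9-fold lower number from compound 1 to compound 2 (0.77 log units; beyond the scatter), and it can be traced to configuration because of the fact that compounds 1 and 2 differ only in the configuration as drawn. Compound 3 `CCCCCCCC/C=C\c1c(C)c(/C=C/CCCCCCCC)c2[n+](c1C)CCC2` has not yet been measured. It relates to compound 2 as follows: the two compounds have the same atoms and bonds and differ only in configuration as drawn: 2 of 2 stereo elements differ; a double bond is drawn E in compound 2 and Z in compound 3; a double bond is drawn Z in compound 2 and E in compound 3. Compound 3 therefore keeps one double bond drawn E and one drawn Z, as compound 2 at 4 uM does, whereas compound 1 at 23.5 uM has both drawn Z. The measured step bears on this change only indirectly, so little movement is expected, perhaps slightly upward and not clearly beyond the scatter. The expected change is a 1.5-fold higher number from compound 2 to compound 3 (0.18 log units; within the scatter). For compound 3 the estimated value is 6 uM, with an expected range of 2.5 uM to 18 uM.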

Compound 3, half-maximal toxic concentration: 3.3 uM
The estimate for compound 3 lay 1.8-fold (0.26 log units) above the measured number; measured number inside the range.
By their numbers in this assay, from the lowest: compounds 3 and 2 (each within the scatter of the next); then compound 1.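

In this assay, exchanging which of the two double bonds is drawn E makes no difference that can be told from the scatter, with a 1.2-fold lower number from compound 2 to compound 3 (0.08 log units; within the scatter). Changing the other double bond from Z to E gives a 7.1-fold lower number from compound 1 to compound 3 (0.85 log units; beyond the scatter), so a single E double bond goes with the lower number at either of the two places, not at just one of them. All of these steps can be traced to configuration alone, since the atoms and bonds stay the same: the fact that compounds 1 and 3 differ only in the configuration as drawn

The compounds shown leave open what the number would be with both double bonds drawn E, and so whether a second E double bond would lower it further. They also leave open how a longer chain, a fully saturated chain or a terminal carboxylic acid on these chains would read in this assay.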